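The source may report more compounds than this note shows. Statements on the series, on what has been measured and on what is new or still open speak of the compounds shown alone.

Compound 1 (`Cc1cc(C)cc(SCc2ccc(/C=C/C(=O)Nc3ccccc3N)cc2)c1`): 2.49%
Compound 2 (`Nc1ccccc1NC(=O)/C=C/c1ccc(CSc2ccc(F)cc2)cc1`): 24.6%

In a functional assay on A-375 cells (Homo sapiens) for inhibition, read by CCK-8 assay, with a stated time of 72 h, tested at 8 uM (a lower number here means less inhibition of growth, a higher number more inhibition of growth at the concentration tested), compound 2 stands higher of the two measured compounds, with 24.6% against compound 1 at 2.49% for the same read-out. Compound 3 (`Nc1ccccc1NC(=O)/C=C/c1ccc(CSc2cccc3ccccc23)cc1`) carries naphthalen-1-yl in place of 4-fluorophenyl on a sulfur. For the measured compounds named here, only one measured step changes the group at this place (a number 22.1 percentage points higher from compound 1 to compound 2 (beyond the scatter)). It shows that the number can move with this group, but not which way a new group will take it. A modest downward step is expected, though one within the scatter would be no surprise (a number 8.6 percentage points lower from compound 2 to compound 3 (within the scatter)). For compound 3 the estimated value is 16%, with an expected range from 3% to 42% in this measurement.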

Compound 3, percent growth inhibition at one concentration: 36%
Compound 3: middle estimate off by 20 percentage points, on the low side; low and high end bracket the measured number.
By their numbers in this assay, from the lowest: compound 1; then compound 2; then compound 3.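

The change to naphthalen-1-yl gives a number 11.4 percentage points higher from compound 2 to compound 3 (beyond the scatter) in this assay, so a second aromatic ring on the sulfur goes with more growth inhibition here, not less. The same group gives a number 33.5 percentage points higher from compound 1 to compound 3 (beyond the scatter) when set against 3,5-dimethylphenyl, and it now ranks above both single-ring groups shown. This position therefore tolerates more than a substituted phenyl ring at this concentration.

From the compounds shown here alone, whether a saturated cyclohexyl group or a pyridin-3-yl ring would hold this level on the sulfur remains open. Nothing available explains why naphthalen-1-yl gives the higher number.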